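The source may hold more compounds than are shown below. What is called first, only, known or untested is meant among the compounds shown, and "the series" means these compounds.

Compound 1 `COc1c(F)c(F)cc(-c2nnc(COc3cnn(C(C)(C)C)c(=O)c3Cl)o2)c1F` in a functional assay on the whole organism for inhibition, with Mythimna separata as the target, with a stated time of 5 days (a lower number here means that less compound is needed, a higher number that more compound is needed for the effect), gives > 300 ug/mL.
Compound 2 `CC(C)(C)n1ncc(OCc2nnc(-c3cccs3)o2)c(Cl)c1=O` gives > 300 ug/mL.
Compound 3 `CC(C)(C)n1ncc(OCc2nnc(-c3c(F)cccc3F)o2)c(Cl)c1=O` gives 45.4 ug/mL.

Compound 1 stands at the limit of this assay (the limit of > 300 ug/mL in this assay, at which 2 of the 3 values shown sit), so its value is a limit and not a number, and nothing more precise is known about where it lies. Compound 4 `CC(C)(C)n1ncc(OCc2nnc(-c3cc(F)c(F)c(F)c3F)o2)c(Cl)c1=O` differs from compound 1 in one place: fluoro in place of methoxy on an aromatic carbon. Among the measured compounds shown here, the only measured step with a number at both ends is that from compound 2 to compound 3, which concerns a different change on the aromatic ring, and it gave an at least 6.6-fold lower number from compound 2 to compound 3 (0.82 log units; beyond the scatter). That step does not involve a methoxy group and bears only loosely on the present change. Since compound 1 is known only as a limit, the step from compound 1 to compound 4 cannot be sized from a measured number. Compound 4 is expected, with wide uncertainty, to give about 150 ug/mL, between 40 ug/mL and 500 ug/mL, which corresponds to an estimated step of an at least 2.0-fold lower number from compound 1 to compound 4 (0.30 log units; that floor lies within the scatter).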

Compound 4, half-maximal effective concentration: 241 ug/mL
Beside the measured number, compound 4's estimate is 1.6-fold (0.21 log units) below it; measured number inside the range.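

Fluoro in place of methoxy at this position, ortho to two fluoro groups, gives a measured number in this assay, whereas the methoxy compound gave only a limit. The step is an at least 1.2-fold lower number from compound 1 to compound 4 (0.09 log units; that floor lies within the scatter), so this single change can leave the limit behind, but the floor alone does not establish a real gain. As far as these compounds go, the true size of the step stays unknown, since compound 1 sits at a limit: the limit of > 300 ug/mL in this assay, at which 2 of the 4 values shown sit.

Still open, from the compounds shown here alone, is how hydrogen, chloro, an amine or a longer chain such as ethoxy would behave at this same position. Also open is whether swapping methoxy for fluoro has a similar effect on a ring with a different fluoro pattern, as no pair shown tests that.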